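Cytotoxicity notes on the shared-core amide series

This account rests on a few compounds, and the source may have more. Where it says the series, first, only, none or still open, it means among the compounds named here.

Measured compounds:
- compound 1 `CC(C)(NC(=O)OCc1ccccc1)c1nc(O)c(O)c(C(=O)N/N=C/c2ccc(F)cc2)n1`: in an ADME assay on C8166 cells (Homo sapiens) for cytotoxicity, read by MTT assay, with a stated time of 3 days (a lower number here means that less compound is tolerated, a higher number that more compound is tolerated), compound 1 gives 378000 nM
- compound 2 `CC(C)(NC(=O)OCc1ccccc1)c1nc(O)c(O)c(C(=O)NCC2CC2)n1`: compound 2 gives 204000 nM
- compound 3 `COCCNC(=O)Nc1nc(C(C)(C)NC(=O)OCc2ccccc2)nc(O)c1O`: for compound 3 only a limit of the assay is recorded, > 500000 nM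

Compound 1 holds the highest of the two numbers shown; compound 2 is nearest, and a 1.9-fold lower number from compound 1 to compound 2 (0.27 log units; within the scatter). That step also swaps the group on the amide-type nitrogen, so two aryl or alkyl substituents there give numbers that cannot be told apart. Going by the values given here, the only step beyond the scatter is an at least 2.4-fold higher number from compound 2 to compound 3 (0.38 log units; beyond the scatter), and its size is bounded because the value of compound 3 sits at the limit of > 500000 nM in this assay, at which 1 of the 3 values shown sits; it concerns a different position and does not bear on the present change.

Compound 4 `CC(C)(NC(=O)OCc1ccccc1)c1nc(O)c(O)c(C(=O)NCc2ccc(C(F)(F)F)cc2)n1` differs from compound 1 by a group of 11 heavy atoms (8 carbon, 3 fluorine; one six-membered aromatic ring of carbon only) in place of a group of 9 heavy atoms (7 carbon, 1 nitrogen, 1 fluorine; one six-membered aromatic ring of carbon only), on an amide-type nitrogen. Among the compounds with values here, the one relevant step, from compound 1 to compound 2, stayed within the scatter, so no movement beyond the scatter is expected here either. Compound 4 is therefore estimated at 320000 nM, with a range from 160000 nM to 500000 nM. The expected step is a 1.2-fold lower number from compound 1 to compound 4 (0.07 log units; within the scatter).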

Compound 4, half-maximal cytotoxic concentration: 58100 nM
The estimate for compound 4 lay 5.5-fold (0.74 log units) above the measured number, outside the stated range (below it).
By their numbers in this assay, from the lowest: compound 4; then compounds 2 and 1 (each within the scatter of the next). At a limit, above all of these: compound 3.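

The amide-type nitrogen is not indifferent to its substituent in this assay: with 4-(trifluoromethyl)benzyl on this nitrogen there is a 6.5-fold lower number from compound 1 to compound 4 (0.81 log units; beyond the scatter), and against the cyclopropylmethyl amide there is a 3.5-fold lower number from compound 2 to compound 4 (0.55 log units; beyond the scatter). Compounds 1 and 2 alone gave numbers within the scatter of each other, so only compound 4 shows that a change at this position can move the tolerated concentration beyond the scatter, and here it moves it towards less compound tolerated. No measurement at hand accounts for this step.

On these data alone, whether the step belongs to the trifluoromethyl group or to the benzyl part of the new substituent remains open. An unsubstituted benzyl on the same amide-type nitrogen would separate the two, and a carboxylic acid on that benzyl would show how far the trend extends.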